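Dimethylamino in place of methoxy on the shared core

The compounds below may be only part of what the source reports. "The series", "measured", "known", "first", "only" and "open" are said of these compounds alone.

Measured in an assay on a protein complex for inhibition of ubiquitin carboxyl-terminal hydrolase 1/WD repeat-containing protein 48 (Homo sapiens), read by fluorescence; on this read-out lower numbers stand for stronger inhibition and higher numbers for weaker inhibition:
compound 1 `Cc1ccc(CNc2nc(-c3ccccc3C(F)(F)F)nc3ccccc23)s1`: 5100 nM
compound 2 `COc1cnc(-c2ccccc2C(C)C)nc1NCc1ccc(-c2cccnc2)cc1`: 70 nM

Compound 2 has the lower of the two numbers in this assay; compound 1 sits far above it, a gap beyond the scatter. Compound 3 `CC(C)c1ccccc1-c1ncc(N(C)C)c(NCc2ccc(-c3cccnc3)cc2)n1` keeps the core of compound 2 and differs only by dimethylamino in place of methoxy on an aromatic carbon. Going by the values given here, no pair of measured compounds shows this change, so its size is unknown. Compound 3 is expected to stay close to compound 2, with at most a step of a 1.4-fold higher number from compound 2 to compound 3 (0.15 log units; within the scatter), not beyond the scatter. The estimate for compound 3 in this assay is 100 nM, expected between 35 nM and 300 nM.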

Compound 3, half-maximal inhibitory concentration: 190 nM
For compound 3 the middle estimate is 1.9-fold (0.28 log units) below the measured one; the measured number falls inside the stated range.
By their numbers in this assay, from the lowest: compound 2; then compound 3; then compound 1.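

In this assay, going by these compounds alone, dimethylamino in place of methoxy gives a 2.7-fold higher number from compound 2 to compound 3 (0.43 log units; beyond the scatter) as the first reading at this position, a modest step beyond the scatter. The aromatic carbon para to a 2-isopropylphenyl group therefore responds to this exchange, yet inhibition is not lost with methoxy gone. No available evidence accounts for the step. Open, on these data alone, is whether methoxy itself matters or only the entering dimethylamino group costs inhibition. Methylamino, a primary amine, ethoxy or plain hydrogen on this carbon would separate those readings.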